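This account rests on a few compounds, and the source may have more. Where it says the series, first, only, none or still open, it means among the compounds named here.

In a functional assay on U-87MG ATCC cells (Homo sapiens) for cytotoxicity, read by MTT assay, with a stated time of 48 h (a lower number here means a stronger inhibitor, a higher number a weaker inhibitor), compound 3 `CC(=NNC(=S)Nc1cccc(I)c1)c1ccccn1` gives 84 nM. This sits level, within the scatter, with compound 1 `CC(=NNC(=S)Nc1cccc([N+](=O)[O-])c1)c1ccccn1` at 69 nM, whereas compound 2 `C/C(=N/NC(=S)Nc1ccccc1)c1ccccn1` gives a far lower 1.4 nM.

Compound 4 `CC(=NNC(=S)Nc1ccccc1)c1ccccn1` follows from compound 3 by hydrogen in place of iodo on an aromatic carbon, meta to a large group: hydrogen in place of iodo on an aromatic carbon.

Among the compounds with values here, the one measured step at this place is a 1.2-fold higher number from compound 1 to compound 3 (0.09 log units; within the scatter). It exchanges nitro for iodo and stays within the scatter, so it does not show what removing the group does. Compound 2 is the better guide: at 1.4 nM, it has the same atoms and connections as compound 4, and only its drawing fixes the geometry of the carbon-nitrogen double bond. The data do not show whether that geometry matters, so some allowance upward remains.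

A large drop beyond the scatter is therefore expected, with an estimated 28-fold lower number from compound 3 to compound 4 (1.45 log units; beyond the scatter). For compound 4, the expected value in this assay is 3 nM, with an estimated range from 0.8 nM to 40 nM.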

Compound 4, half-maximal inhibitory concentration: 1.4 nM
Compound 4: middle estimate off by 2.1-fold (0.33 log units), on the high side; the range from low to high includes it.
By their numbers in this assay, from the lowest: compounds 2 and 4 (each within the scatter of the next); then compounds 1 and 3 (each within the scatter of the next).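

Removing the group at this place, rather than exchanging it, is what moves the number: a 60-fold lower number from compound 3 to compound 4 (1.78 log units; beyond the scatter) and a 49-fold lower number from compound 1 to compound 4 (1.69 log units; beyond the scatter), both large, whereas nitro and iodo read level with each other. In this assay, hydrogen on this aromatic carbon therefore gives a far lower number than either of the two groups shown there. The remaining pair gives no change at the digits printed from compound 2 to compound 4 (within the scatter), but it cannot settle whether the geometry of the double bond matters, and the limit lies in how the two are drawn: the fact that one of compounds 2 and 4 is drawn with a defined configuration and the other without, at the place where they differ.

From the compounds shown here alone, only iodo and nitro stand against hydrogen here, so it remains open whether any group on this carbon raises the number this far. A fluoro or methyl group could keep the number close to that of hydrogen or raise it just as much, and an amine might behave differently again.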